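This account rests on a few compounds, and the source may have more. Where it says the series, first, only, none or still open, it means among the compounds named here.

Measured compounds:
compound 1 `Cc1nc(SCC(=O)Nc2nc(-c3ccc(Cl)cc3)cs2)n(Nc2ccccc2)c1C` — 3720 nM
compound 2 `Cc1ccc(Nn2c(SCC(=O)Nc3nc(-c4ccccc4)cs3)nc(C)c2C)cc1` — 19300 nM

Both numbers come from a functional assay on LOX IMVI cells (Homo sapiens) for antiproliferative activity, read by sulforhodamine B assay, with a stated time of 48 h; a higher number here means a weaker inhibitor of growth, a lower number a stronger inhibitor of growth. Compound 1 stands at the lower of the two, and its gap to compound 2 lies beyond the scatter, so compound 1 is the stronger growth inhibitor of the pair. For the measured compounds named here, compound 2 differs from compound 1 in more than one place, so no single-change step joins them.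

Compound 3 `COc1ccc(Nn2c(SCC(=O)Nc3nc(-c4ccc(Cl)cc4)cs3)nc(C)c2C)cc1` differs from compound 1 by methoxy in place of hydrogen on an aromatic carbon — methoxy in place of hydrogen on an aromatic carbon, para to a large group. Going by the values given here, no measured pair isolates this change. In this assay a modest step toward a higher number is expected, since compound 2, which carries a substituted anilino ring but also lacks the chloro, gives 19300 nM. Compound 3 is therefore estimated at 6000 nM, within 2500 nM to 15000 nM, a step of a 1.6-fold higher number from compound 1 to compound 3 (0.21 log units; within the scatter) that is expected to stay close to the scatter.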

Compound 3, concentration for total growth inhibition: 44200 nM
Compound 3: the middle estimate sits 7.4-fold (0.87 log units) below what was measured, outside the stated range (above it).
By their numbers in this assay, from the lowest: compound 1; then compound 2; then compound 3.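

Methoxy in place of hydrogen on an aromatic carbon of the anilino ring, para to a large group, is the first single-place change in the series, and in this assay it gives a 12-fold higher number from compound 1 to compound 3 (1.07 log units; beyond the scatter) with the rest of the structure held fixed. This position is therefore not indifferent to substitution, and in this pair the unsubstituted phenyl of compound 1 gives the stronger growth inhibition. Nothing available bears on the reason for this step.

From the compounds shown here alone, it remains open whether this step is specific to methoxy or extends to other groups at the same place, such as a hydroxyl, a fluoro or an amine. Also open, going by these compounds, is whether the change from phenyl to 4-methoxyphenyl gives a step of this size in a compound without the chloro group.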